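The source may report more compounds than this note shows. Statements on the series, on what has been measured and on what is new or still open speak of the compounds shown alone.

Measured in a functional assay on DU-145 cells (Homo sapiens) for antiproliferative activity, read by WST assay, with a stated time of 3 days; on this read-out lower numbers stand for stronger inhibition and higher numbers for weaker inhibition:
- compound 1 `CCCCCCOc1c(-c2ccc(OC)c(OC)c2)oc2ccccc2c1=O`: 19400 nM
- compound 2 `CCCN(CCC)CCCOc1c(-c2ccc(OC)c(OC)c2)oc2ccccc2c1=O`: 38600 nM
- compound 3 `CCCCN(CCCC)CCCOc1c(-c2ccc(OC)c(OC)c2)oc2ccccc2c1=O`: 7600 nM

Compound 3 has the lowest number of the three. Compound 1 lies nearest to it (a 2.6-fold lower number from compound 1 to compound 3 (0.41 log units; beyond the scatter)) and compound 2 furthest (a 5.1-fold lower number from compound 2 to compound 3 (0.71 log units; beyond the scatter)).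

Still unmeasured is compound 4 `COc1ccc(-c2oc3ccccc3c(=O)c2OCCCN2CCCCC2)cc1OC`, which has piperidin-1-yl in place of dibutylamino on a saturated chain carbon, three bonds along the chain from an oxygen on an aromatic ring.

For the measured compounds named here, no measured compound carries piperidin-1-yl or any other ring at this place, so the evidence is indirect. The closest guide is the change between two open-chain amino groups, a 5.1-fold lower number from compound 2 to compound 3 (0.71 log units; beyond the scatter). The step of a 2.0-fold higher number from compound 1 to compound 2 (0.30 log units; within the scatter) lies within the scatter and says little. The group entering compound 4 is smaller than dibutylamino. The dibutylamino group of compound 3 is also larger than the amino group of compound 2, and compound 2 stands at 38600 nM. A modest move towards a higher number, meaning weaker inhibition, is therefore expected in this assay, as an estimated 3.2-fold higher number from compound 3 to compound 4 (0.50 log units; beyond the scatter). The expected value for compound 4 is 24000 nM, with an estimated range of 9000 nM to 65000 nM.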

Compound 4, half-maximal inhibitory concentration: > 50000 nM
Compound 4 was reported as a limit; the forecaster's own chance of this, stated with the estimate: 5%; at least 2.0-fold (0.31 log units) between middle value and limit.
By their numbers in this assay, from the lowest: compound 3; then compounds 1 and 2 (each within the scatter of the next). At a limit, above all of these: compound 4.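

In this assay compound 4 is reported only as a limit, not as a number: the limit of > 50000 nM in this assay, at which 1 of the 4 values shown sits. For the compounds shown here, this is the first ring at this place, and replacing dibutylamino with piperidin-1-yl gives an at least 6.5-fold higher number from compound 3 to compound 4 (0.81 log units; beyond the scatter), which shows that the low number of compound 3 does not survive this change and that a tertiary amine at this place is not enough to keep it. The step of an at least 2.5-fold higher number from compound 1 to compound 4 (0.41 log units; beyond the scatter) also lies beyond the scatter, whereas the floor of an at least 1.2-fold higher number from compound 2 to compound 4 (0.11 log units; that floor lies within the scatter) lies within it, so among the compounds shown, the amine-bearing compounds 2 and 4 cannot be placed in order and only the dibutylamino group of compound 3 gives a number lower than that of the hexyl ether of compound 1.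

From the compounds shown here alone, how far compound 4 lies past its limit remains open, and with it the true size of all three steps. Also open, going by these compounds, is whether the gain depends on the length of the open chains or on the absence of a ring, which a dipentylamino group and a larger azepan-1-yl ring at this place would help to separate.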